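The source may report more compounds than this note shows. Statements on the series, on what has been measured and on what is new or still open speak of the compounds shown alone.

Compounds measured so far:
Compound 1, `CCCC[C@@H](O)C(=O)N1[C@@H]2C[C@@H]2C[C@H]1C(=O)NCc1cc(Cl)ccc1-n1cnnn1` — 870 nM
Compound 2, `O=C(NCc1cc(Cl)ccc1-n1cnnn1)[C@@H]1C[C@@H]2C[C@@H]2N1C(=O)[C@H](O)c1ccccc1` — 620 nM

In a functional assay on a cell-free system (plasma, Homo sapiens), with a stated time of 3 min (on this read-out higher numbers stand for weaker inhibition and lower numbers for stronger inhibition), compound 1 gives 870 nM. Compound 2 gives 620 nM. On these two numbers compound 2 stands lowest, but the gap to compound 1 lies within the scatter of the measurement, so the two values show no difference that can be read as a change.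

The next compound in this account is compound 3, `O=C(NCc1cc(Cl)ccc1-n1cnnn1)[C@@H]1C[C@H]2C[C@H]2N1C(=O)[C@H](O)c1ccccc1`, which is not yet measured. It departs from compound 2 only in configuration: the two compounds have the same atoms and bonds and differ only in configuration as drawn: 2 of 4 stereo elements differ; a stereocentre at a saturated ring carbon is drawn S in compound 2 and R in compound 3; a stereocentre at a saturated ring carbon is drawn S in compound 2 and R in compound 3. The two stereocentres that change are both at saturated ring carbons, so the shared core is drawn with the opposite configuration at those positions while the rest of the molecule is kept.

Among the compounds with values here, no step between measured compounds is available to calibrate such a change. A change at two ring stereocentres is expected to shift the number in this assay beyond the scatter, towards weaker inhibition, because compound 2 already gives 620 nM and a diastereomer of a shaped core is more likely to lose than to gain. The step from compound 2 to compound 3 is thus estimated as a 4.8-fold higher number from compound 2 to compound 3 (0.68 log units; beyond the scatter).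

Compound 3 is expected to give about 3000 nM, with a range from 800 nM to 15000 nM.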

Compound 3, half-maximal inhibitory concentration in the Homo sapiens assay: 680 nM
Estimate against measurement, compound 3: 4.4-fold (0.64 log units) above; measured number below the stated range.
By their numbers in the Homo sapiens assay, from the lowest: compounds 2, 3 and 1 (each within the scatter of the next).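

In the Homo sapiens assay there is a 1.1-fold higher number from compound 2 to compound 3 (0.04 log units; within the scatter), so at this core the two ring stereocentres drawn the opposite way give no difference that can be read, and this pair tests configuration alone: the fact that compounds 2 and 3 differ only in the configuration as drawn. In a physicochemical assay for solubility, measured as kinetic solubility, at pH 6.8 (a higher number here means a more soluble compound, a lower number a less soluble compound), compound 2 gives 97000 nM and compound 3 gives 100000 nM, with a 1.0-fold higher number from compound 2 to compound 3 (0.01 log units; within the scatter), so the same change leaves these two solubility values indistinguishable as well. Back in the Homo sapiens assay, the pairing with the butyl compound gives a 1.3-fold lower number from compound 1 to compound 3 (0.11 log units; within the scatter), so phenyl in place of butyl on the saturated chain carbon also yields no readable difference in this set.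

All three inhibition values lie within the scatter of one another. The compounds shown do not yet identify any structural change that moves this number. On these data alone, whether a carboxylic acid, an amine or a longer chain in place of the phenyl or butyl would move the inhibition or solubility beyond the scatter remains open, as does whether the insensitivity to configuration would hold with such groups.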